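Isobutyl to sec-Butyl on an Amine in Caco-2 Inhibition

The source may report more compounds than this note shows. Statements on the series, on what has been measured and on what is new or still open speak of the compounds shown alone.

Measured compounds:
compound 1, `CCC(C)NC(=C\C(=O)/C=C/c1ccc(O)c(OC)c1)/C=C/c1ccc(O)c(OC)c1`: > 25000 nM
compound 2, `COc1cc(/C=C/C(=O)/C=C(/C=C/c2ccc(OC(C)=O)c(OC)c2)NCC(C)C)ccc1OC(C)=O`: > 25000 nM
compound 3, `COc1cc(/C=C/C(=O)/C=C(/C=C/c2ccc(O)c(OC)c2)NCC(C)C)ccc1O`: > 25000 nM

In an ADME assay on Caco-2 cells (Homo sapiens) for inhibition, read by sulforhodamine B assay, with a stated time of 72 h (on this read-out lower numbers stand for stronger inhibition and higher numbers for weaker inhibition), compound 1 gives > 25000 nM, which is a limit of the assay and not a number. In this assay compound 2 gives > 25000 nM, also a limit. In this assay compound 3 gives > 25000 nM, again a limit. The change from compound 3 to compound 1 is sec-butyl in place of isobutyl on an amine nitrogen, and its step is a step that the two limits leave unreadable from compound 3 to compound 1 because of the limit of > 25000 nM in this assay, at which 3 of the 3 values shown sit. The difference between the cores of compound 2 and compound 3 is not broken down here. Compound 4, `CCC(C)NC(=C\C(=O)/C=C/c1ccc(OC(C)=O)c(OC)c1)/C=C/c1ccc(OC(C)=O)c(OC)c1`, has not been measured; it differs from compound 2 by sec-butyl in place of isobutyl on an amine nitrogen, the same change. For compound 4 the expected step is a step that the limit leaves unreadable from compound 2 to compound 4, resting on the unreadable step from compound 3 to compound 1. Compound 4 is therefore expected at 40000 nM, likely also reported only as a limit.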

Compound 4, half-maximal inhibitory concentration: > 25000 nM
Compound 4 was reported as a limit (the forecaster's own chance of this, stated with the estimate: 90%); the middle value is on the limit's open side.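

The step between compound 2 and compound 4 cannot be read, because both compounds are reported only as a limit: the limit of > 25000 nM in this assay, at which 4 of the 4 values shown sit. The compounds shown leave open whether sec-butyl in place of isobutyl on an amine nitrogen changes inhibition at all.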